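Shortening the acyl chain of a liponucleotide diphosphate

The compounds below may be only part of what the source reports. "The series", "measured", "known", "first", "only" and "open" are said of these compounds alone.

Measured so far:
compound 1 `CCCCCCCCCCCCCCCCOCC(COP(=O)(O)OP(=O)(O)OC[C@H]1OC(n2ccc(N)nc2=O)[C@@H](O)[C@@H]1O)OC(=O)CCCCCCCCCCCCCCC` — 130000 nM
compound 2 `CCCCCCCCCCCCCCCC(=O)OC(COCCCCCCCCCCCC)COP(=O)(O)OP(=O)(O)OC[C@H]1OC(n2ccc(N)nc2=O)[C@@H](O)[C@@H]1O` — a limit, > 131000000 nM
compound 3 `CCCCCCCCCCCCCCCC(=O)OC(COCCCCCCCCCCCCCC)COP(=O)(O)OP(=O)(O)OC[C@H]1OC(n2ccc(N)nc2=O)[C@@H](O)[C@@H]1O` — a limit, > 43000000 nM

Among the measured compounds shown here, in a physicochemical assay for solubility, tested at 272 nM (on this read-out lower numbers stand for lower solubility and higher numbers for higher solubility), compound 1 gives 130000 nM, the only number among the three values shown. Compound 2 sits at a limit, (the limit of > 131000000 nM in this assay, at which 1 of the 3 values shown sits). Compound 3 sits at a limit, (the limit of > 43000000 nM in this assay, at which 1 of the 3 values shown sits).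

Compound 4 `CCCCCCCCCCCCCCCCOCC(COP(=O)(O)OP(=O)(O)OC[C@H]1OC(n2ccc(N)nc2=O)[C@@H](O)[C@@H]1O)OC(=O)CCCCCCCCCCC` differs from compound 1 by hydrogen in place of butyl on a saturated chain carbon, ten or more bonds along the chain from a carbonyl carbon. The measured steps that bear on this are an at least 1000-fold higher number from compound 1 to compound 2 (3.00 log units; beyond the scatter) and an at least 330-fold higher number from compound 1 to compound 3 (2.51 log units; beyond the scatter), both removals of chain carbons from a saturated chain carbon, there on the ether-linked chain. A large upward step is therefore expected; the expected step is a 100-fold higher number from compound 1 to compound 4 (2.00 log units; beyond the scatter). Compound 4 is estimated at 13000000 nM, with a range from 1000000 nM to 200000000 nM, and a limit rather than a number is a real possibility.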

Compound 4, solubility: > 132000000 nM
Compound 4: only a limit was reported (the forecaster's own chance of this, stated with the estimate: 50%); at least 10-fold (1.00 log units) between middle value and limit.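

In this assay, hydrogen in place of butyl on a saturated chain carbon, ten or more bonds along the chain from a carbonyl carbon, gives an at least 1000-fold higher number from compound 1 to compound 4 (3.00 log units; beyond the scatter). The earlier large steps lay on the ether-linked chain, so this is the first large step shown on the acyl chain. Compound 4 stands at a limit, not a number: the limit of > 132000000 nM in this assay, at which 1 of the 4 values shown sits.

Steps between compounds that both sit at limits cannot be read. As far as these compounds go, whether an intermediate acyl chain or an amine at the end of that chain would give a number in this assay stays open.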